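Third aryl variation at the shared core

The source may hold more compounds than are shown below. What is called first, only, known or untested is meant among the compounds shown, and "the series" means these compounds.

Compound 2 `CC(C)(C)Cc1c(-c2cn[nH]c2)sc(N)c1C(=O)c1ccc(Cl)cc1` carries a 1H-pyrazol-4-yl group on the shared core, and in an assay on CHO cells for displacement of a labelled ligand from adenosine receptor A1 (Homo sapiens), read by scintillation counting, tested at 10 uM (on this read-out higher numbers stand for more inhibition at the one concentration tested (going by the name of the read-out) and lower numbers for less inhibition), compound 2 gives 1%. Within the data shown here, its only measured neighbour is compound 1 `CC(C)(C)Cc1c(-c2ccccc2)sc(N)c1C(=O)c1ccc(Cl)cc1`, which bears a phenyl group at the same carbon; in this assay compound 1 gives 1%. The step of no change at the digits printed from compound 1 to compound 2 (within the scatter) shows that exchanging phenyl for 1H-pyrazol-4-yl left the read-out where it was, so compound 2 stands level with compound 1 at the digits given. Compound 3 `CC(C)(C)Cc1c(-c2ccsc2)sc(N)c1C(=O)c1ccc(Cl)cc1` continues the series: thiophen-3-yl in place of 1H-pyrazol-4-yl on an aromatic carbon. Among the measured compounds shown here, the one measured step that bears on this kind of exchange, no change at the digits printed from compound 1 to compound 2 (within the scatter), was flat, and both compound 1 and compound 2 rest at the same low level of inhibition at the single concentration tested. For the measured compounds named here, no measured step involves a thiophen-3-yl group, so nothing in the data argues for a departure from that level. Compound 3 is therefore expected to show a step of a number 1 percentage points higher from compound 2 to compound 3 (within the scatter), that is, no movement beyond the scatter in this assay. Compound 3 is estimated at 2%, with a range from -8% to 12%.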

Compound 3, a percentage reported as inhibition, at one concentration (the size of the read-out at that concentration, not a potency): 2%
Beside the measured number, compound 3's estimate shows no gap at the digits printed, within the range that was stated.
By their numbers in this assay, from the lowest: compounds 1, 2 and 3 (each within the scatter of the next).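

The step of a number 1 percentage points higher from compound 2 to compound 3 (within the scatter) in this assay shows that the read-out at this carbon, next to the ring sulfur, holds when a 1H-pyrazol-4-yl group with 1 hydrogen-bond donor gives way to a thiophen-3-yl group with 0 hydrogen-bond donors and a sulfur in its ring. The step of a number 1 percentage points higher from compound 1 to compound 3 (within the scatter) adds a second comparison, this time with the phenyl group, so three different aromatic groups at this one carbon now read within the scatter of each other, all close to no inhibition at the single concentration tested. No supporting information accompanies these numbers to explain why the read-out stays so flat at this position.

The compounds shown leave open whether any group at this carbon can lift the read-out at all, for example an amine, a carboxylic acid or a longer chain in place of the aromatic ring. They also leave open whether such flatness holds when the neopentyl group or the amino group on the shared core is exchanged, since both stay the same in all three compounds.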